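This account rests on a few compounds, and the source may have more. Where it says the series, first, only, none or still open, it means among the compounds named here.

Measured compounds:
compound 1, `O=C(Nc1ccc(Cl)cc1)c1c(O)c2cccnc2n(-c2ccccc2)c1=O`: 2.5%
compound 2, `O=C(Nc1ccc([N+](=O)[O-])cc1)c1c(O)c2cccnc2n(-c2ccccc2)c1=O`: -25.8%
compound 3, `O=C(Nc1cccc(Cl)c1)c1c(O)c2cccnc2n(-c2ccccc2)c1=O`: 13.4%

Of the compounds shown here, three on a shared core have been tested in a functional assay on the whole organism for inhibition, with Rattus norvegicus as the target, read by cytopathic effect and paw edema, at a dose of 100 mg/kg by the oral route; a lower number here means less inhibition, a higher number more inhibition at the dose given (going by the name of the read-out). Compound 1 gives 2.5%. Compound 2 carries the change nitro in place of chloro on an aromatic carbon and gives -25.8%; the step is a number 28.3 percentage points lower from compound 1 to compound 2 (beyond the scatter). Compound 3 differs from compound 1 in its core by 3-chlorophenyl in place of 4-chlorophenyl on an amide-type nitrogen. Compound 3 gives 13.4%, the step being a number 10.9 percentage points higher from compound 1 to compound 3 (beyond the scatter). Between compound 2 and compound 3 the step is a number 39.2 percentage points higher from compound 2 to compound 3 (beyond the scatter). Compound 3 thus stands highest of the three, with both steps to it beyond the scatter.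

Compound 4, `O=C(Nc1cccc([N+](=O)[O-])c1)c1c(O)c2cccnc2n(-c2ccccc2)c1=O`, has not yet been measured. It differs from compound 3 by nitro in place of chloro on an aromatic carbon. Among the measured compounds shown here, this is the same kind of change as the one from compound 1 to compound 2, but the place is not the same: in compound 2 the nitro sits para to a large group, in compound 4 it sits meta to a large group. For the measured compounds named here, with only one earlier example of this change, the expectation rests on that single step, a number 28.3 percentage points lower from compound 1 to compound 2 (beyond the scatter), taken as a guide, while allowing that the differing place may blunt or sharpen it. The expected step is a number 23.4 percentage points lower from compound 3 to compound 4 (beyond the scatter) in this assay. The estimate for compound 4 is -10%. The expected range for compound 4 is estimated to run from -35% to 12%.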

Compound 4, a percentage reported as inhibition, in the whole organism at one dose (the size of the read-out at that dose, not a potency): 7.4%
Compound 4: middle estimate off by 17.4 percentage points, on the low side; measured number inside the range.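

In this assay, nitro in place of chloro on the 3-chlorophenyl group gives a number 6 percentage points lower from compound 3 to compound 4 (within the scatter), so the change does not carry its size over from the 4-chlorophenyl compound: the same change on two cores in this assay, a number 28.3 percentage points lower (beyond the scatter) from compound 1 to compound 2 and a number 6 percentage points lower (within the scatter) from compound 3 to compound 4, 22.3 percentage points apart, beyond the scatter of two such steps

Among the nitro compounds, 3-nitrophenyl in place of 4-nitrophenyl gives a number 33.2 percentage points higher from compound 2 to compound 4 (beyond the scatter), while 3-nitrophenyl in place of 4-chlorophenyl gives a number 4.9 percentage points higher from compound 1 to compound 4 (within the scatter), which leaves compound 2 as the only one of the four set apart from all the others, at the low end, in this assay. Among the compounds shown here, this shows that the effect of swapping chloro for nitro cannot be assumed to be the same wherever the group sits on the aromatic ring, but with only two pairs it gives no rule for other groups or other places, and the numbers alone do not say why the two steps part.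

The compounds shown leave open whether a methoxy group, an amine or a carboxylic acid on the same aromatic ring would follow the low value of compound 2 or the values of the other three. They also leave open whether the pattern would hold if a longer chain replaced the phenyl group on the ring nitrogen of the shared core.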